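A few compounds are considered here, and "the series" means these few. Any claim that something is new, unique, unknown or untested is made for them only; others in the source may bear on it.

Measured so far in an ADME assay on microsomes from liver (Mus musculus) for metabolic stability, read by LC-MS; a lower number here means slower removal, a higher number faster removal of the compound:

Compound 1 `CC1CCC(NC(=O)c2cc3c(Cl)cc(Cl)cc3[nH]2)CC1`; in this assay compound 1 gives 37 mL.min-1.g-1.
Compound 2 `CC1CCC(NC(=O)c2cc3c(F)cc(F)cc3[nH]2)CC1`; in this assay compound 2 gives 866 mL.min-1.g-1.
Compound 3 `CC1(C)CCC(NC(=O)c2cc3c(Cl)cc(Cl)cc3[nH]2)CC1`; in this assay compound 3 gives 13 mL.min-1.g-1.

Compound 1 and compound 2 carry the same saturated ring and amide link but different cores; the difference between the two cores is not broken down here. What the two values show is that compound 2 sits far above compound 1 in this assay, beyond the scatter, and further still above compound 3, which is the lowest of the three numbers.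

Within the core of compound 1, one change has been measured: methyl in place of hydrogen on a saturated ring carbon. It produced a 2.8-fold lower number from compound 1 to compound 3 (0.45 log units; beyond the scatter), a modest but real step.

Compound 4 `CC1(C)CCC(NC(=O)c2cc3c(F)cc(F)cc3[nH]2)CC1` applies the same change to compound 2: methyl in place of hydrogen on a saturated ring carbon. The place is described in the same words for both pairs, so this is the same change on the other core.

In this assay the step from compound 2 to compound 4 is expected to be a 2.6-fold lower number from compound 2 to compound 4 (0.42 log units; beyond the scatter), resting on the step seen from compound 1 to compound 3, a 2.8-fold lower number from compound 1 to compound 3 (0.45 log units; beyond the scatter), with added width because compound 2 gives 866 mL.min-1.g-1, a very high starting number where repeat scatter may be larger. The estimate for compound 4 in this assay is therefore 330 mL.min-1.g-1, with a likely range from 150 mL.min-1.g-1 to 800 mL.min-1.g-1.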

Compound 4, intrinsic clearance in microsomes: 132 mL.min-1.g-1
Estimate against measurement, compound 4: 2.5-fold (0.40 log units) above; measured number below the stated range.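

In this assay, methyl in place of hydrogen on a saturated ring carbon again lowers the number on the core of compound 2, with a 6.6-fold lower number from compound 2 to compound 4 (0.82 log units; beyond the scatter). Set beside the earlier step, the change goes the same way on both cores, and the two sizes cannot be told apart: the same change on two cores in this assay, a 2.8-fold lower number (0.45 log units; beyond the scatter) from compound 1 to compound 3 and a 6.6-fold lower number (0.82 log units; beyond the scatter) from compound 2 to compound 4, 2.3-fold (0.36 log units) apart, within the scatter of two such steps. Going by these compounds alone, for this series, the change therefore carries from the core of compound 1 to the core of compound 2 in both direction and size within the scatter, but this rests on only two matched pairs and does not show that it would hold on any further core, nor does it show why the number falls.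

The compounds shown leave open whether the step depends on methyl itself or would also appear with another group on the same saturated ring carbon, such as ethyl, a hydroxyl group or trifluoromethyl. They also leave open whether it would persist on a core carrying neither chlorine nor fluorine, for example one bearing a nitrile or a methoxy group instead.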